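Ethyl to Isopropyl on the Amine-Bearing Chain Carbon

The source may report more compounds than this note shows. Statements on the series, on what has been measured and on what is new or still open speak of the compounds shown alone.

Compound 1 `CC[C@@H](Nc1c(Nc2cccc(C(=O)N(C)C)c2O)c(=O)c1=O)c1cc(C)cs1`: 24 nM
Compound 2 `CC[C@@H](Nc1c(Nc2cccc(C(=O)N(C)C)c2O)c(=O)c1=O)c1cc(C)co1`: 9 nM
Compound 3 `CC[C@@H](Nc1c(Nc2cccc(C(=O)N(C)C)c2O)c(=O)c1=O)c1cc(C(C)C)co1`: 3 nM

Of the compounds shown here, three built on a shared core have been measured in an assay on CHO cells for displacement of a labelled ligand from C-X-C chemokine receptor type 1 (Homo sapiens); a lower number here means a stronger inhibitor, a higher number a weaker inhibitor. Compound 3 stands lowest of the three. Its nearest neighbour is compound 2, separated by a 3.0-fold lower number from compound 2 to compound 3 (0.48 log units; beyond the scatter). Compound 1 lies furthest away, separated by an 8.0-fold lower number from compound 1 to compound 3 (0.90 log units; beyond the scatter). The remaining pair is linked by a 2.7-fold lower number from compound 1 to compound 2 (0.43 log units; beyond the scatter).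

Compound 4 `CC(C)c1coc([C@H](Nc2c(Nc3cccc(C(=O)N(C)C)c3O)c(=O)c2=O)C(C)C)c1` has not yet been measured in this assay. It differs from compound 3 by methyl in place of hydrogen on a saturated chain carbon bound to two saturated chain carbons. Among the measured compounds shown here, none of the measured steps alters this position: the steps from compound 1 touch the heteroaryl ring, and the step from compound 2 to compound 3 adds carbon to an aromatic carbon, not to the saturated chain carbon bound to two saturated chain carbons. The only growth of a methyl into an isopropyl that has been seen, from compound 2 to compound 3, gave a modest gain, but at a different place, so it cannot be carried over directly. Given this, the expected step in this assay is no change at the digits printed from compound 3 to compound 4 (within the scatter), meaning no change beyond the scatter. Compound 4 is therefore estimated at 3 nM, with a range from 1 nM to 10 nM.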

Compound 4, inhibition constant: 11 nM
Compound 4: the middle estimate sits 3.7-fold (0.56 log units) below what was measured; the measured number lies above the stated range.
By their numbers in this assay, from the lowest: compound 3; then compounds 2 and 4 (each within the scatter of the next); then compound 1.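

In this assay the saturated chain carbon bound to two saturated chain carbons proves sensitive to change: replacing hydrogen with methyl there, which turns ethyl into isopropyl, gives a 3.7-fold higher number from compound 3 to compound 4 (0.56 log units; beyond the scatter) and so a weaker inhibitor. The earlier compounds shown here all kept the ethyl chain and varied only the aromatic group, where the one growth of methyl into isopropyl gave a 3.0-fold lower number from compound 2 to compound 3 (0.48 log units; beyond the scatter) and so ran in the opposite direction, which shows that the same added carbon does not act alike at these two places. Nothing measured here explains why the branched chain gives the weaker binding.

From the compounds shown here alone, what remains open is whether this shift depends on the aromatic group, since this single step was read only with the 4-isopropylfuran-2-yl group in place and not with the 4-methylfuran-2-yl or 4-methylthiophen-2-yl group. The compounds shown also leave open how this chain position would respond to a cyclopropyl group, a longer chain such as propyl, or a chain ending in an amine or a hydroxyl.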